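Ethyl to Methyl: Cytotoxicity Expected to Stay Level

The compounds below may be only part of what the source reports. "The series", "measured", "known", "first", "only" and "open" are said of these compounds alone.

The measured compounds, with their readings in an ADME assay on MDCK cells (Canis lupus familiaris) for cytotoxicity, read by microscopy, with a stated time of 48 h; on this read-out higher numbers stand for lower toxicity in this test and lower numbers for higher toxicity in this test:
- compound 1 `CCCc1ccsc1CN[C@@H]1C[C@H]2C[C@@H]([C@H]1C)C2(C)C`: 50000 nM
- compound 2 `CCc1csc(CN[C@@H]2C[C@H]3C[C@@H]([C@H]2C)C3(C)C)c1`: 25000 nM
- compound 3 `C[C@H]1[C@H](NCc2sccc2C2CC2)C[C@H]2C[C@@H]1C2(C)C`: 25000 nM

All three share the same core and amine link and differ only in the group on the aromatic ring. Compound 2 stands level with compound 3 at the digits shown, the two together giving the lowest numbers of the three, and compound 1 sits a step above them, though that step is within the scatter.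

Compound 4 `Cc1csc(CN[C@@H]2C[C@H]3C[C@@H]([C@H]2C)C3(C)C)c1` is the unmeasured partner of compound 2. The difference is hydrogen in place of methyl on a saturated chain carbon bound to an aromatic carbon.

Going by the values given here, the one measured step that alters this same group is a 2.0-fold lower number from compound 1 to compound 3 (0.30 log units; within the scatter), and it stayed within the scatter. Among the compounds with values here, no measured pair shortens the chain in the way compound 4 does, so the comparison is indirect. With every measured change at this position leaving the number within the scatter, the expectation for compound 4 in this assay is no step beyond the scatter, as no change at the digits printed from compound 2 to compound 4 (within the scatter).

Compound 4 is therefore estimated at 25000 nM, with a range from 12500 nM to 50000 nM.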

Compound 4, minimum cytotoxic concentration: 12500 nM
The estimate for compound 4 lay 2.0-fold (0.30 log units) above the measured number; the measured number falls inside the stated range.
By their numbers in this assay, from the lowest: compounds 4, 2, 3 and 1 (each within the scatter of the next, the first and the last beyond it).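

Going from ethyl to methyl gives a 2.0-fold lower number from compound 2 to compound 4 (0.30 log units; within the scatter) in this assay. Going by these compounds alone, this is the first reading of a chain shortened at this place, on a saturated chain carbon bound to an aromatic carbon, so the effect of removing one carbon from the chain no longer has to be inferred from the step that swaps propyl for cyclopropyl. It shows that this small cut leaves the reading within the usual scatter of the test, although nothing available explains the reading.

All the groups in this part of the study are small hydrocarbon groups: methyl, ethyl, propyl and cyclopropyl. Going by these compounds, it remains open whether a longer chain such as butyl, or a group of a different kind such as an amine or a carboxylic acid, would also stay within the scatter.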